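The source may report more compounds than this note shows. Statements on the series, on what has been measured and on what is new or still open speak of the compounds shown alone.

Measured so far in one cytotoxicity read-out:
compound 1 `O=C1NC(=S)/C(=C/c2cc(Cl)cc(Cl)c2Cl)S1` — 22.8%
compound 2 `O=C1NC(=S)/C(=C/c2cccc(Cl)c2)S1` — 17.6%
compound 3 `O=C1NC(=S)/C(=C/c2ccc(Cl)c(Cl)c2)S1` — 11%

In a functional assay on HEp-2 cells (Homo sapiens) for cytotoxicity, read by MTT assay, with a stated time of 72 h, tested at 5 ug/mL (on this read-out higher numbers stand for more inhibition of growth at the one concentration tested and lower numbers for less inhibition of growth), compound 2 gives 17.6%, the second highest of the three numbers; compound 1 lies closest and compound 3 furthest, yet both gaps fall within the scatter, so the three cannot be ranked against each other. Going by the values given here, the only measured step, a number 6.6 percentage points lower from compound 2 to compound 3 (within the scatter), exchanged hydrogen for chloro on an aromatic carbon and stayed within the scatter. Compound 4 `O=C1NC(=S)/C(=C/c2cccc(Br)c2)S1` differs from compound 2 by bromo in place of chloro on an aromatic carbon. Among the compounds with values here, no measured step swaps one halogen for another, so nothing here points to a change beyond the scatter. Compound 4 is therefore expected to give 18%, between 8% and 30%. That estimate means a step of a number 0.4 percentage points higher from compound 2 to compound 4 (within the scatter), expected to stay within the scatter.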

Compound 4, percent growth inhibition at one concentration: -1.04%
For compound 4 the middle estimate is 19 percentage points above the measured one; measured number outside the range, below it.
By their numbers in this assay, from the lowest: compound 4; then compounds 3, 2 and 1 (each within the scatter of the next, the first and the last beyond it).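

In this assay, exchanging one halogen for another on this aromatic carbon gives a step beyond the scatter, a number 18.6 percentage points lower from compound 2 to compound 4 (beyond the scatter). Going by these compounds alone, the earlier step, a number 6.6 percentage points lower from compound 2 to compound 3 (within the scatter), stayed within the scatter, so this is the first sign that a single atom can shift the reading, though it rests on one pair of compounds. Nothing available explains why the bromo compound reads this way.

The compounds shown leave open how fluoro, methoxy or an amine would read on this same carbon. They also leave open whether bromo on another carbon of the ring would give a similar step.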